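A few compounds are considered here, and "the series" means these few. Any claim that something is new, unique, unknown or untested is made for them only; others in the source may bear on it.

Measured compounds:
compound 1 `O=C(CCC1CCCC1)N(O)c1ccc(Cl)cc1` – 20000 nM
compound 2 `O=C(C1CCCCC1)N(O)c1ccc(Cl)cc1` – 40000 nM
compound 3 `O=C(CC1CCCCC1)N(O)c1ccc(Cl)cc1` – 9000 nM

In a functional assay on HEp-2 cells (Homo sapiens) for inhibition (a lower number here means a stronger inhibitor, a higher number a weaker inhibitor), compound 1 gives 20000 nM, the second highest of the three numbers; compound 2 sits within the scatter of it, and compound 3 is the furthest from it, with the step of a 2.2-fold lower number from compound 1 to compound 3 (0.35 log units; beyond the scatter). The unmeasured compound 4 `O=C(CCC1CCCCC1)N(O)c1ccc(Cl)cc1` differs from compound 1 in one place: cyclohexyl in place of cyclopentyl on a saturated chain carbon, two bonds along the chain from a carbonyl carbon. Among the measured compounds shown here, the only measured step that bears on it is the one from compound 1 to compound 3, a 2.2-fold lower number from compound 1 to compound 3 (0.35 log units; beyond the scatter), where a cyclohexyl took the place of a cyclopentylmethyl; that change, however, both enlarged the ring and shortened the chain, whereas the change to compound 4 enlarges the ring and keeps the chain. Compound 2 and compound 3, both carrying a cyclohexyl, show that the longer chain went with the lower number in this pair. On that basis a modest step downward is expected in this assay, a 2.0-fold lower number from compound 1 to compound 4 (0.30 log units; within the scatter), and compound 4 is estimated at 10000 nM, with a range from 4000 nM to 30000 nM.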

Compound 4, half-maximal inhibitory concentration: 30000 nM
For compound 4 the middle estimate is 3.0-fold (0.48 log units) below the measured one; low and high end bracket the measured number.
By their numbers in this assay, from the lowest: compound 3; then compounds 1, 4 and 2 (each within the scatter of the next).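

In this assay, changing the ring alone, with cyclohexyl in place of cyclopentyl and the chain kept, gives a 1.5-fold higher number from compound 1 to compound 4 (0.18 log units; within the scatter), so ring size does not separate these two compounds at this place. With the cyclohexyl held fixed, compound 2 gives 40000 nM, compound 3 gives 9000 nM and compound 4 gives 30000 nM: the number does not fall steadily as the chain lengthens, and compound 4 goes against the trend suggested by compound 2 and compound 3 alone. Nothing available accounts for this result.

The compounds shown leave open whether a cycloheptyl or a phenyl at this place would separate from the cyclopentyl of compound 1. They also leave open how a longer chain carrying the cyclohexyl would compare with compound 4.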